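Difluoromethoxyphenyl in Place of Chlorophenyl on a Nucleoside

A few compounds are considered here, and "the series" means these few. Any claim that something is new, unique, unknown or untested is made for them only; others in the source may bear on it.

Compound 1, `OC[C@H]1O[C@@H](n2cnc3c(NCc4ccc(Cl)cc4)ncnc32)[C@H](O)[C@@H]1O`, gives in a functional assay on G-361 cells (Homo sapiens) for antiproliferative activity, with a stated time of 72 h (on this read-out lower numbers stand for stronger inhibition and higher numbers for weaker inhibition), only a limit, > 166000 nM. Compound 2, `OC[C@H]1O[C@@H](n2cnc3c(NCc4c(F)ccc(F)c4F)ncnc32)[C@H](O)[C@@H]1O`, likewise gives only a limit in this assay, > 166000 nM. Compound 3, `COc1cccc(CNc2ncnc3c2ncn3[C@@H]2O[C@H](CO)[C@@H](O)[C@H]2O)c1O`, gives 148000 nM in this assay. The step of an at least 1.1-fold lower number from compound 1 to compound 3 (0.04 log units; that floor lies within the scatter) and the step of an at least 1.1-fold lower number from compound 2 to compound 3 (0.04 log units; that floor lies within the scatter) both stay within the scatter, while a step that the two limits leave unreadable from compound 1 to compound 2. Compound 1 thus stands at the limit of > 166000 nM in this assay, at which 2 of the 3 values shown sit, with no readable order among the three compounds. Compound 4, `OC[C@H]1O[C@@H](n2cnc3c(NCc4ccccc4OC(F)F)ncnc32)[C@H](O)[C@@H]1O`, differs from compound 1 by 2-(difluoromethoxy)phenyl in place of 4-chlorophenyl on a saturated chain carbon bound to a nitrogen on an aromatic ring. For the measured compounds named here, no measured step exchanges the 4-chlorophenyl for a group of this kind, and all three known values sit close together, so no step beyond the scatter is expected. The estimate for compound 4 is 160000 nM, between 70000 nM and 350000 nM. That estimate means the step of an at least 1.0-fold lower number from compound 1 to compound 4 (0.01 log units; that floor lies within the scatter) is expected to remain within the scatter.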

Compound 4, half-maximal inhibitory concentration: > 166000 nM
Compound 4: a limit, no number (the forecaster's own chance of this, stated with the estimate: 60%); middle value at least 1.0-fold (0.01 log units) away from the limit.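

In this assay compound 4 gives only a limit, > 166000 nM. The steps that join it to compound 1 and compound 2 run between two limits and cannot be read, so 2-(difluoromethoxy)phenyl in place of 4-chlorophenyl on this saturated chain carbon yields no number. The one readable step, an at least 1.1-fold higher number from compound 3 to compound 4 (0.04 log units; that floor lies within the scatter), stays within the scatter, and the limit now holds most of the series: the limit of > 166000 nM in this assay, at which 3 of the 4 values shown sit.

As far as these compounds go, whether an amine or a carboxylic acid carried on the phenyl ring in this place would give a value clear of that limit stays open. From the compounds shown here alone, the true size of every step ending at a limit also stays open.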